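A few compounds are considered here, and "the series" means these few. Any claim that something is new, unique, unknown or untested is made for them only; others in the source may bear on it.

In a functional assay on A549 cells (Homo sapiens) for cytotoxicity, read by MTT assay (on this read-out lower numbers stand for stronger inhibition and higher numbers for weaker inhibition), compound 1 `C=C1C(=O)O[C@H]2C/C(C)=C/[C@@H](O)C/C(C)=C/CC/C(C)=C/C[C@H]12` gives a value that is only a limit of the assay, > 5 ug/mL. Compound 2 `C=C1C(=O)O[C@H]2/C=C(\C)CC/C=C(\CO)CC/C=C(\C)CC[C@@H]12`, which carries a hydroxymethyl group on a double-bonded ring carbon, likewise yields only a limit of the assay in this assay, > 5 ug/mL. Compound 2 thus stands at the limit, where both shown values sit (the limit of > 5 ug/mL in this assay, at which 2 of the 2 values shown sit). Compound 3 `C=C1C(=O)O[C@H]2/C=C(\C)CC/C=C(\C(=O)OC)CC/C=C(\C)CC[C@@H]12` has not yet been measured in this assay; it differs from compound 2 by methoxycarbonyl in place of hydroxymethyl on a double-bonded ring carbon, a methoxycarbonyl in place of the hydroxymethyl on a double-bonded ring carbon of the 14-membered non-aromatic ring of carbon only. No step between measured compounds is at hand, and with both shown values resting at the limit, compound 3 is expected to show no step beyond the scatter from compound 2, a step that the limit leaves unreadable from compound 2 to compound 3. Compound 3 is therefore estimated at 8 ug/mL, within 3 ug/mL to 25 ug/mL, most likely again reported as a limit.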

Compound 3, half-maximal inhibitory concentration: > 5 ug/mL
Compound 3: a limit, no number; the forecaster's own chance of this, stated with the estimate: 70%; the middle value is on the limit's open side.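

Compound 2 and compound 3 both rest only on a limit of the assay, so no step can be read between them: the limit of > 5 ug/mL in this assay, at which 3 of the 3 values shown sit.

The compounds shown leave open whether methoxycarbonyl in place of hydroxymethyl on a double-bonded ring carbon changes the read-out at all.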